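A few compounds are considered here, and "the series" means these few. Any claim that something is new, unique, unknown or untested is made for them only; others in the source may bear on it.

Compounds measured so far:
compound 1 `Nc1nc(C(F)(F)F)cc2c1[nH]c(=O)n2Cc1ccc(NCCN2CCCCC2)nc1` — 16 mL.min-1.g-1
compound 2 `Nc1nc(C(F)(F)F)cc2c1[nH]c(=O)n2Cc1ccc(NCc2ccccc2)nc1` — 16 mL.min-1.g-1

In an in vitro ADME assay on microsomes from liver (Rattus norvegicus) for pharmacokinetics (on this read-out higher numbers stand for fast clearance and lower numbers for slow clearance), compound 1 gives 16 mL.min-1.g-1, and compound 2 gives 16 mL.min-1.g-1. Compound 2 therefore stands level with compound 1 at the digits shown; the single measured step, no change at the digits printed from compound 1 to compound 2 (within the scatter), lies within the scatter, so nothing can be said about an order between the two.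

Compound 3 `CN(C)CCNc1ccc(Cn2c(=O)[nH]c3c(N)nc(C(F)(F)F)cc32)cn1` differs from compound 2 in one place: (dimethylamino)methyl in place of phenyl on a saturated chain carbon bound to a nitrogen on an aromatic ring. Within the data shown here, the only measured step that bears on this is the one from compound 1 to compound 2, in which phenyl replaced (piperidin-1-yl)methyl at the same place without moving the read-out. Compound 3 returns to a chain of that kind, so no step beyond the scatter is expected in this assay. The expected step is no change at the digits printed from compound 2 to compound 3 (within the scatter). Compound 3 is estimated at 16 mL.min-1.g-1, with a range from 8 mL.min-1.g-1 to 32 mL.min-1.g-1.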

Compound 3, intrinsic clearance in microsomes: 16 mL.min-1.g-1
Beside the measured number, compound 3's estimate shows no gap at the digits printed; the measured number falls inside the stated range.
By their numbers in this assay, from the lowest: compounds 1, 2 and 3 (each within the scatter of the next).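

At this position, on a saturated chain carbon bound to a nitrogen on an aromatic ring, the change of phenyl to (dimethylamino)methyl in this assay gives no change at the digits printed from compound 2 to compound 3 (within the scatter), so the flat reading now extends to a second amine-bearing chain. The new pair also isolates the amine itself: dimethylamino in place of piperidin-1-yl, an open group for a ring, gives no change at the digits printed from compound 1 to compound 3 (within the scatter). No measurement at hand offers a reason for these readings.

From the compounds shown here alone, it remains open whether a carboxylic acid, a morpholine or a longer chain at this place would separate from these three compounds in this assay. The compounds shown also leave open whether the same changes would read alike on a core without the trifluoromethyl group.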